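The source may report more compounds than this note shows. Statements on the series, on what has been measured and on what is new or still open speak of the compounds shown alone.

Measured so far:
compound 1 `C[C@@H](NC(=O)Nc1ccc(C(C)(C)C)cc1)c1ccccc1` — 100%
compound 2 `CCCCCCc1ccc(NC(=O)N[C@H](C)c2ccccc2)cc1` — 100%
compound 3 `CCCCCCc1ccc(NC(=O)N[C@@H](C)c2ccccc2)cc1` — 99%

All three numbers come from an ADME assay on the whole organism with Oryza sativa as the target, tested at 0.1 uM; a lower number here means a stronger effect, a higher number a weaker effect of the compound at the concentration tested. On these numbers compound 2 stands level with compound 1, and the two together give the highest readings of the three. The closest neighbour of compound 2 is compound 1, with no change at the digits printed from compound 1 to compound 2 (within the scatter); the furthest is compound 3, with a number 1 percentage points lower from compound 2 to compound 3 (within the scatter), a step that stays within the scatter, which fits (the fact that compounds 2 and 3 differ only in the configuration as drawn).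

Compound 4 `C[C@@H](NC(=O)Nc1ccc(I)cc1)c1ccccc1` has not yet been measured. It differs from compound 2 in one place: iodo in place of hexyl on an aromatic carbon. For the measured compounds named here, the only measured step that also changes the group on that aromatic carbon is the one from compound 1 to compound 2, where no change at the digits printed from compound 1 to compound 2 (within the scatter). On that basis no step beyond the scatter is expected in this assay for the change to iodo, in either direction.

Compound 4 is therefore estimated at 97%, with a range from 85% to 100%. This estimate means an expected step of a number 3 percentage points lower from compound 2 to compound 4 (within the scatter).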

Compound 4, a percentage reported as activity, at one concentration (the size of the read-out at that concentration, not a potency): 100%
Estimate against measurement, compound 4: 3 percentage points below; low and high end bracket the measured number.
By their numbers in this assay, from the lowest: compounds 3, 1, 2 and 4 (each within the scatter of the next).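

In this assay, for the compounds shown here, the earlier compounds varied this aromatic carbon only between two carbon groups, tert-butyl and hexyl. Iodo brings in a single iodine atom, a different kind of group with 1 heavy atom in place of the 6 of hexyl, yet no change at the digits printed from compound 2 to compound 4 (within the scatter) and no change at the digits printed from compound 1 to compound 4 (within the scatter) show that this replacement also leaves the reading unmoved. Across these three groups, then, the group at this position does not separate the compounds at the concentration tested, and nothing measured here gives a reason for that.

Going by these compounds, what stays open is whether any group at this position can lower the number at all, for example an amine, a carboxylic acid or a nitrile. Changes elsewhere on the shared core also remain an open question.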